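The source may hold more compounds than are shown below. What is called first, only, known or untested is meant among the compounds shown, and "the series" means these compounds.

Values in a functional assay on MCF7 cells (Homo sapiens) for antiproliferative activity, read by MTT assay, with a stated time of 3 days; a lower number here means a stronger inhibitor, a higher number a weaker inhibitor:
- compound 1 `Cc1ccc(C#Cc2cn(C/C=C\CN3C(=O)c4ccccc4C3=O)c(=O)[nH]c2=O)cc1`: > 100000 nM, a limit
- compound 2 `CCCCCCCCC#Cc1cn(C/C=C\CN2C(=O)c3ccccc3C2=O)c(=O)[nH]c1=O`: 64000 nM
- compound 3 `CCCCCc1ccc(C#Cc2cn(C/C=C\CN3C(=O)c4ccccc4C3=O)c(=O)[nH]c2=O)cc1`: > 100000 nM, a limit

Compound 3 gives only a limit, > 100000 nM. That is the limit of > 100000 nM in this assay, at which 2 of the 3 values shown sit.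

Compound 4 `CCCCC#Cc1cn(C/C=C\CN2C(=O)c3ccccc3C2=O)c(=O)[nH]c1=O` carries butyl in place of 4-pentylphenyl on a triple-bonded carbon. The closest precedents are the exchanges between aryl and octyl groups at that place: an at least 1.5-fold lower number from compound 1 to compound 2 (0.19 log units; that floor lies within the scatter) and an at least 1.5-fold higher number from compound 2 to compound 3 (0.19 log units; that floor lies within the scatter). Neither shows a step beyond the scatter. Going by the values given here, compound 2, with octyl, is the only compound with a number, 64000 nM, and no shorter chain has been measured. A small step to a lower number is expected, and it may not be readable: an at least 1.1-fold lower number from compound 3 to compound 4 (0.04 log units; that floor lies within the scatter). For compound 4 the expected value is 90000 nM, with an estimated range of 40000 nM to 200000 nM.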

Compound 4, half-maximal inhibitory concentration: 45000 nM
For compound 4 the middle estimate is 2.0-fold (0.30 log units) above the measured one; measured number inside the range.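

At this triple-bonded carbon, replacing an aryl group with an alkyl chain now gives steps beyond the scatter, which the octyl compound did not show: an at least 2.2-fold lower number from compound 3 to compound 4 (0.34 log units; beyond the scatter) and an at least 2.2-fold lower number from compound 1 to compound 4 (0.34 log units; beyond the scatter). Both steps are only floors, because compound 1 and compound 3 each give a limit: the limit of > 100000 nM in this assay, at which 2 of the 4 values shown sit. In this assay, butyl and octyl are not told apart: a 1.4-fold lower number from compound 2 to compound 4 (0.15 log units; within the scatter).

On these data alone, whether a chain shorter than butyl, such as ethyl, would give a lower number remains open. So does the effect of an amine or a carboxylic acid at the end of the chain.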